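Removing the Methoxy Group from Compound 3

The compounds below may be only part of what the source reports. "The series", "measured", "known", "first", "only" and "open" are said of these compounds alone.

Of the compounds shown here, three have been tested in a functional assay on UO-31 cells (Homo sapiens) for inhibition, read by sulforhodamine B assay, with a stated time of 48 h, tested at 10 uM; on this read-out higher numbers stand for more inhibition of growth at the one concentration tested and lower numbers for less inhibition of growth. Compound 1 `COc1cc(-c2nc(N)n(CC(=O)Nc3ccc(/C(C)=N\O)cc3)n2)cc(OC)c1OC` gives 20.5%, compound 2 `c1ccc(-c2nc3sc(-c4ccccc4)cn3n2)cc1` gives 53%, and compound 3 `COc1ccc(-c2nc3sc(-c4ccc(Cl)cc4)cn3n2)cc1` gives -7.46%, the lowest of the three, with both other numbers lying beyond the scatter above it. Compound 4 `Clc1ccc(-c2cn3nc(-c4ccccc4)nc3s2)cc1` has not yet been measured. It differs from compound 3 in one place: hydrogen in place of methoxy on an aromatic carbon. Among the compounds with values here, no pair of measured compounds shows this same change, so the expectation rests on compound 2, which carries no methoxy and gives 53% in this assay. On that basis a rise is expected, estimated as a number 32.5 percentage points higher from compound 3 to compound 4 (beyond the scatter). Compound 4 is expected to give about 25%, within a range from -5% to 55%.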

Compound 4, percent growth inhibition at one concentration: 40%
The estimate for compound 4 lay 15 percentage points below the measured number; measured number inside the range.
By their numbers in this assay, from the lowest: compound 3; then compound 1; then compound 4; then compound 2.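

In this assay, hydrogen in place of methoxy on the aromatic carbon para to a large group gives a number 47.5 percentage points higher from compound 3 to compound 4 (beyond the scatter), with the chloro group present in both compounds. This position therefore responds strongly to this change. Chloro in place of hydrogen at another aromatic carbon gives a more modest step, a number 13 percentage points lower from compound 2 to compound 4 (beyond the scatter).

No measurement here bears on the reason for either step. As far as these compounds go, whether an amine or an ethoxy group at the methoxy position would give a number nearer compound 3 or compound 4 remains open.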